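Amide substituent variation on the shared dichloroaryl enone core

A few compounds are considered here, and "the series" means these few. Any claim that something is new, unique, unknown or untested is made for them only; others in the source may bear on it.

Working notes on the series. The shared core is that of compound 1, `C=C(CC)C(=O)c1ccc(OCC(=O)NCCO)c(Cl)c1Cl`. In a functional assay on CLL cells (Homo sapiens) for cytotoxicity, read by MTT assay, with a stated time of 48 h (on this read-out higher numbers stand for an effect only at larger amounts of compound and lower numbers for an effect already at smaller amounts), compound 1 gives only a limit, > 25000 nM, and not a number. Compound 1 thus stands at the limit of > 25000 nM in this assay, at which 1 of the 3 values shown sits. Two further compounds carry a ring on the amide nitrogen: compound 2, `C=C(CC)C(=O)c1ccc(OCC(=O)Nc2ccc3c(c2)C(=O)NC3=O)c(Cl)c1Cl`, gives 2500 nM in this assay, and compound 3, `C=C(CC)C(=O)c1ccc(OCC(=O)Nc2ccc3c(c2)C(O)N=NC3O)c(Cl)c1Cl`, gives 8500 nM. Both return numbers where compound 1 returns a limit; for compound 2 against compound 3 no step is computed, and only the two values themselves are shown.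

Compound 4, `C=C(CC)C(=O)c1ccc(OCC(=O)NC(CS)C(=O)OCC)c(Cl)c1Cl`, is not yet measured. It differs from compound 1 in one place: 1-(ethoxycarbonyl)-2-sulfanylethyl in place of 2-hydroxyethyl on an amide-type nitrogen. Among the measured compounds shown here, no measured step of this kind exists, so the size of the move cannot be read from a neighbouring pair. The change keeps the amide nitrogen and exchanges one open-chain substituent for another; the two measured numbers both come from compounds bearing a ring at that nitrogen, and compound 4 has none. The expected step is small, an at least 1.2-fold lower number from compound 1 to compound 4 (0.09 log units; that floor lies within the scatter), with a fair chance that the result is again a limit. Compound 4 is estimated at 20000 nM, within 6000 nM to 50000 nM.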

Compound 4, half-maximal effective concentration: 4800 nM
Compound 4: the middle estimate sits 4.2-fold (0.62 log units) above what was measured, and the stated range ends above it.
By their numbers in this assay, from the lowest: compounds 2, 4 and 3 (each within the scatter of the next, the first and the last beyond it). At a limit, above all of these: compound 1.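

At the amide nitrogen, an open-chain substituent can return a number in this assay, whereas the earlier numbers came only from compound 2 and compound 3, which bear a ring at that nitrogen. Exchanging 2-hydroxyethyl for 1-(ethoxycarbonyl)-2-sulfanylethyl gives an at least 5.2-fold lower number from compound 1 to compound 4 (0.71 log units; beyond the scatter), so among the compounds shown, a ring at this nitrogen is not required for a measurable effect. This step is a floor and not an exact size, because compound 1 stands at a limit of the assay: the limit of > 25000 nM in this assay, at which 1 of the 4 values shown sits.

The compounds shown do not separate the contributions of the sulfanyl and ethoxycarbonyl parts of the entering group, and no cause for the step can be assigned from them. On these data alone, it remains open whether a plain 2-sulfanylethyl chain, a 1-(ethoxycarbonyl)-2-hydroxyethyl group or a carboxylic acid in place of the ethyl ester would preserve the step seen with compound 4 in this assay.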